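A few compounds are considered here, and "the series" means these few. Any claim that something is new, unique, unknown or untested is made for them only; others in the source may bear on it.

Of the compounds shown here, three sharing one core have been tested. Compound 1 `COc1cccc(/C=C/C(=O)c2ccc(OC)c3c2OC(C)(C)C=C3)c1` gives 9360 nM in a functional assay on SK-OV-3 cells (Homo sapiens) for antiproliferative activity, read by MTT assay, with a stated time of 24 h; on this read-out higher numbers stand for weaker inhibition and lower numbers for stronger inhibition. Compound 2 `COc1ccc(C(=O)/C=C/c2ccccc2)c2c1C=CC(C)(C)O2` reaches only the limit of this assay, > 10000 nM, which is not a number. Compound 3 `CCOc1cc(/C=C/C(=O)c2ccc(OC)c3c2OC(C)(C)C=C3)ccc1O` likewise sits at the limit, > 10000 nM. Going by the values given here, the only measured single change, an at least 1.0-fold higher number from compound 1 to compound 2 (0.02 log units; that floor lies within the scatter), removes a methoxy group and lands at the limit of > 10000 nM in this assay, at which 2 of the 3 values shown sit. Compound 4 `COc1ccc(C(=O)/C=C/c2ccc(O)c(Br)c2)c2c1C=CC(C)(C)O2` differs from compound 3 by bromo in place of ethoxy on an aromatic carbon. Among the compounds with values here, no measured step involves an ethoxy or a bromo group, and since two of the three values already sit at the limit, no step beyond the scatter is expected for a step that the limit leaves unreadable from compound 3 to compound 4. Compound 4 is therefore estimated at 12000 nM, between 4000 nM and 40000 nM in this assay.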

Compound 4, half-maximal inhibitory concentration: > 10000 nM
Compound 4: only a limit was reported; the forecaster's own chance of this, stated with the estimate: 60%; the middle value is on the limit's open side.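

With bromo on the aromatic carbon ortho to a hydroxy group, compound 4 gives > 10000 nM in this assay as a limit, not a number. The steps to compound 4 from compound 2 and compound 3 cannot be read, and the one that can is an at least 1.0-fold higher number from compound 1 to compound 4 (0.02 log units; that floor lies within the scatter) and so gives no measure of how 3-bromo-4-hydroxyphenyl compares with 3-methoxyphenyl. Most of the set now rests at one value: the limit of > 10000 nM in this assay, at which 3 of the 4 values shown sit.

Going by these compounds, it remains open whether any group at this place gives a true number in this assay. An amine or a carboxylic acid in place of the bromo could answer that.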